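Methoxy for nitro on the benzoyl of a P2X7 antagonist

The source may report more compounds than this note shows. Statements on the series, on what has been measured and on what is new or still open speak of the compounds shown alone.

Compound 1 `O=C(NC1CC1)c1cccc(S(=O)(=O)Oc2ccc(-c3cncn3C3CCN(C(=O)c4ccc(Cl)c(C(F)(F)F)c4)CC3)cc2)c1`: 88 nM
Compound 2 `CNC(=O)c1cccc(S(=O)(=O)Oc2ccc(-c3cncn3C3CCN(C(=O)c4ccc(OC)cc4)CC3)cc2)c1`: 159 nM
Compound 3 `O=C(NC1CC1)c1cccc(S(=O)(=O)Oc2ccc(-c3cncn3C3CCN(C(=O)c4ccc([N+](=O)[O-])cc4)CC3)cc2)c1`: 152 nM

In an assay on HEK293 cells for antagonist activity at P2X purinoceptor 7 (Homo sapiens), read by fluorescence, with a stated time of 2 h (a higher number here means a weaker inhibitor, a lower number a stronger inhibitor), compound 3 stands second highest of the three numbers, and both compound 1 and compound 2 lie within the scatter of it. Compound 4 `COc1ccc(C(=O)N2CCC(n3cncc3-c3ccc(OS(=O)(=O)c4cccc(C(=O)NC5CC5)c4)cc3)CC2)cc1` differs from compound 3 only at the aryl of the carbonyl: methoxy in place of nitro on an aromatic carbon. Within the data shown here, the one measured step that bears on this position, a 1.7-fold higher number from compound 1 to compound 3 (0.24 log units; within the scatter), stayed within the scatter. Compound 2, which carries the same methoxyphenyl carbonyl as compound 4 but a methylamide in place of the cyclopropylamide, shows a value close to compound 3. Compound 4 is therefore expected to show no step beyond the scatter, a 1.1-fold lower number from compound 3 to compound 4 (0.04 log units; within the scatter), and its estimated value is 140 nM, from 70 nM to 280 nM.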

Compound 4, half-maximal inhibitory concentration: 244 nM
Estimate against measurement, compound 4: 1.7-fold (0.24 log units) below; the measured number falls inside the stated range.
By their numbers in this assay, from the lowest: compounds 1, 3, 2 and 4 (each within the scatter of the next, the first and the last beyond it).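

In this assay, methoxy in place of nitro on an aromatic carbon gives a step within the scatter (a 1.6-fold higher number from compound 3 to compound 4 (0.21 log units; within the scatter)), as does cyclopropyl in place of methyl on the amide nitrogen (a 1.5-fold higher number from compound 2 to compound 4 (0.19 log units; within the scatter)). Only the change of the whole aryl on the carbonyl, to 4-methoxyphenyl from the aryl of compound 1, goes modestly beyond the scatter (a 2.8-fold higher number from compound 1 to compound 4 (0.44 log units; beyond the scatter)). No evidence here accounts for these steps. As far as these compounds go, whether an amine, a carboxylic acid or a nitrile at this aromatic carbon would move the number beyond the scatter of compound 3 remains open.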